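Cyano in Place of Methyl on the Benzyl Ring

A few compounds are considered here, and "the series" means these few. Any claim that something is new, unique, unknown or untested is made for them only; others in the source may bear on it.

Compound 1, `O=C(O)c1ccccc1-c1ccc(CCc2ncc(CC3CCCCC3)[nH]2)cc1`, gives 41 nM in an in vitro functional assay on cells for agonist activity at Bombesin receptor subtype-3 (Homo sapiens), read by luminescence and calcium flux; on this read-out lower numbers stand for an effect already at smaller amounts and higher numbers for an effect only at larger amounts of compound.
Compound 2, `Cc1ccccc1Cc1cnc(CCc2ccc(-c3ccccc3C(=O)O)cc2)[nH]1`, gives 127 nM in this assay.
Compound 3, `Cc1cccc(Cc2cnc(CCc3ccc(-c4ccccc4C(=O)O)cc3)[nH]2)c1`, gives 4310 nM in this assay.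

Compound 3 stands at the highest number of the three, separated from its neighbours by a 34-fold higher number from compound 2 to compound 3 (1.53 log units; beyond the scatter) and by a 110-fold higher number from compound 1 to compound 3 (2.02 log units; beyond the scatter). Compound 4, `N#Cc1cccc(Cc2cnc(CCc3ccc(-c4ccccc4C(=O)O)cc3)[nH]2)c1`, differs from compound 3 by cyano in place of methyl on an aromatic carbon. Within the data shown here, none of the measured steps swaps one group for another on this ring; the steps of a 3.1-fold higher number from compound 1 to compound 2 (0.49 log units; beyond the scatter) and a 34-fold higher number from compound 2 to compound 3 (1.53 log units; beyond the scatter) exchange the whole group on the chain carbon. They show that this assay answers strongly to changes in this region, but they point to no direction for compound 4. Compound 4 is therefore expected to stay near compound 3, with an estimated step of a 1.2-fold lower number from compound 3 to compound 4 (0.09 log units; within the scatter). The estimated value for compound 4 is 3500 nM, between 800 nM and 15000 nM.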

Compound 4, half-maximal effective concentration: 812 nM
Compound 4: the middle estimate sits 4.3-fold (0.63 log units) above what was measured; measured number inside the range.
By their numbers in this assay, from the lowest: compound 1; then compound 2; then compound 4; then compound 3.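

In this assay there is a 5.3-fold lower number from compound 3 to compound 4 (0.72 log units; beyond the scatter) when cyano replaces methyl, so this ring carbon, meta to a large group, responds to a small swap and not only to exchanging the whole group. Even so, the 3-cyanobenzyl group does not reach the other groups, with a 6.4-fold higher number from compound 2 to compound 4 (0.81 log units; beyond the scatter) and a 20-fold higher number from compound 1 to compound 4 (1.30 log units; beyond the scatter) still standing. Nothing available gives a reason for these steps.

Still open, from the compounds shown here alone, is whether an amine or a methoxy group on this same carbon would move the number further, and whether cyano would have a similar effect on the ring of compound 2.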